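The source may hold more compounds than are shown below. What is called first, only, known or untested is meant among the compounds shown, and "the series" means these compounds.

Measured so far in a functional assay for antagonist activity at transient receptor potential cation channel subfamily V member 1 (Homo sapiens), read by FLIPR; on this read-out lower numbers stand for stronger inhibition and higher numbers for weaker inhibition:
- compound 1, `O=C(Nc1ccccc1)c1ccc(-c2ncccc2C(F)(F)F)cc1` — > 4000 nM
- compound 2, `Cc1cccnc1-c1ccc(C(=O)Nc2ccc(Cl)cc2)cc1` — 1500 nM
- compound 3, `CCCOc1cccnc1-c1ccc(C(=O)Nc2ccc(C(C)(C)C)cc2)cc1` — 62 nM

Compound 3 stands lowest of the two numbers in this assay; the nearest number is that of compound 2, which lies well beyond the scatter. The value given for compound 1 is a limit of this assay, not a number (the limit of > 4000 nM in this assay, at which 1 of the 3 values shown sits). No pair among these three differs in one place only, so no single change can be read off from the measured compounds.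

Compound 4, `CC(C)(C)c1ccc(NC(=O)c2ccc(-c3ncccc3C(=N)N)cc2)cc1`, is not yet measured. It differs from compound 3 in one place: a group of 3 heavy atoms (1 carbon, 2 nitrogen; no ring) in place of a group of 4 heavy atoms (3 carbon, 1 oxygen; no ring), on an aromatic carbon. Among the compounds with values here, the propoxy group of compound 3 goes with the lowest number seen in this assay, and its removal removes the only feature that sets compound 3 apart in that place from compound 2, whose number is 1500 nM. For compound 4 a step towards weaker inhibition is expected in this assay, of roughly a 24-fold higher number from compound 3 to compound 4 (1.38 log units; beyond the scatter). The estimate for compound 4 in this assay is 1500 nM, within a range from 300 nM to 6000 nM.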

Compound 4, half-maximal inhibitory concentration: > 4000 nM
Compound 4: a limit, no number; the forecaster's own chance of this, stated with the estimate: 30%; at least 2.6-fold (0.42 log units) between middle value and limit.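

Within the data shown here, on the aromatic carbon two atoms from the ring nitrogen, this is the first change that can be read in one place: in this assay, a group of 3 heavy atoms (1 carbon, 2 nitrogen) in place of propoxy gives an at least 64-fold higher number from compound 3 to compound 4 (1.80 log units; beyond the scatter). Compound 4 gives > 4000 nM, which is a limit of the assay and not a number. The position therefore does not accept every small group, and the printed step is only a bound on the true size of the change: the limit of > 4000 nM in this assay, at which 2 of the 4 values shown sit.

The compounds shown do not separate the loss of the propoxy chain from the entry of 2 hydrogen-bond donors in place of 0. Open too, from the compounds shown here alone, is whether a methoxy, a butoxy, an amine or a nitrile at this position would stay near compound 3 or fall to the limit.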